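A few compounds are considered here, and "the series" means these few. Any claim that something is new, unique, unknown or untested is made for them only; others in the source may bear on it.

Measured so far in a functional assay on HCT-116 cells (Homo sapiens) for inhibition, read by MTT assay, with a stated time of 48 h; a lower number here means a stronger inhibitor, a higher number a weaker inhibitor:
compound 1 `C/C=C/C=C/C(=O)N(Cc1ccc(OC)c(O)c1)c1cc(OC)c(OC)c(OC)c1` gives 180 nM
compound 2 `C#CC(=O)N(Cc1ccc(OC)c(O)c1)c1cc(OC)c(OC)c(OC)c1` gives 310 nM
compound 3 `COc1ccc(CN(C(=O)CCCCCl)c2cc(OC)c(OC)c(OC)c2)cc1O` gives 220 nM

Compound 3 holds the second highest of the three numbers; its nearest neighbour is compound 1, which stands a step of a 1.2-fold higher number from compound 1 to compound 3 (0.09 log units; within the scatter) away, and its furthest is compound 2, a step of a 1.4-fold lower number from compound 2 to compound 3 (0.15 log units; within the scatter) away. Neither gap is beyond the scatter, so the three acyl variants on the shared core read as one level.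

The next compound, compound 4 `COc1ccc(CN(C(=O)CBr)c2cc(OC)c(OC)c(OC)c2)cc1O`, keeps the core of compound 3 and differs only on the acyl side: bromo in place of 3-chloropropyl on a saturated chain carbon bound to a carbonyl carbon. For the measured compounds named here, the steps that bear on such an acyl change are those among compounds 1, 2 and 3: a long unsaturated chain, a short unsaturated group and a chlorinated chain all land within the scatter of one another. Nothing in this set shows an acyl change moving this assay beyond the scatter, so no step beyond the scatter is expected here either, and the estimate sits at the level of compound 3. For compound 4 the expected value in this assay is 230 nM, in the range 90 nM to 600 nM, which would be a step of a 1.0-fold higher number from compound 3 to compound 4 (0.02 log units; within the scatter).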

Compound 4, half-maximal inhibitory concentration: 68 nM
Compound 4: the middle estimate sits 3.4-fold (0.53 log units) above what was measured; measured number below the stated range.
By their numbers in this assay, from the lowest: compound 4; then compounds 1, 3 and 2 (each within the scatter of the next).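

In this assay, the acyl side of the shared core now separates the compounds: bromomethyl on the carbonyl carbon gives a 3.2-fold lower number from compound 3 to compound 4 (0.51 log units; beyond the scatter) against 4-chlorobutyl, a 4.6-fold lower number from compound 2 to compound 4 (0.66 log units; beyond the scatter) against ethynyl and a 2.6-fold lower number from compound 1 to compound 4 (0.42 log units; beyond the scatter) against penta-1,3-dien-1-yl, each beyond the scatter, which makes compound 4 the strongest inhibitor of the four. The change shortens the chain and exchanges chlorine for bromine in one step, so the data cannot assign the gain to either part. No measurement shown here accounts for the step.

Still open, as far as these compounds go, is which part carries the gain: chloromethyl, methyl and 4-bromobutyl on the same carbonyl carbon would separate the halogen from the chain length. Also open, from the compounds shown here alone, is whether an amine in place of the bromo keeps the lower number.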